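Amide substituent series: chlorophenyl to chloropyridinyl on the amide nitrogen

The source may report more compounds than this note shows. Statements on the series, on what has been measured and on what is new or still open speak of the compounds shown alone.

Working notes on the series. In a functional assay on U-87MG ATCC cells for inhibition, with U-87 MG (Homo sapiens) as the target, read by MTT assay, with a stated time of 72 h (a lower number here means a stronger inhibitor, a higher number a weaker inhibitor), compound 1 `Cc1noc(C)c1-c1cnc(N)c(Oc2ccc(C(=O)NC3CCCC3)cc2)n1` gives 57600 nM. Compound 2 `Cc1noc(C)c1-c1cnc(N)c(Oc2ccc(C(=O)NC3CCCCC3)cc2)n1` gives 40400 nM in this assay, the step being a 1.4-fold lower number from compound 1 to compound 2 (0.15 log units; within the scatter). Compound 3 `Cc1noc(C)c1-c1cnc(N)c(Oc2ccc(C(=O)Nc3ccc(Cl)cc3)cc2)n1` gives 15500 nM in this assay and stands lowest of the three numbers; the steps of a 3.7-fold lower number from compound 1 to compound 3 (0.57 log units; beyond the scatter) and a 2.6-fold lower number from compound 2 to compound 3 (0.42 log units; beyond the scatter) are both modest. Compound 4 `Cc1noc(C)c1-c1cnc(N)c(Oc2ccc(C(=O)Nc3cccc(Cl)n3)cc2)n1` differs from compound 3 by 6-chloropyridin-2-yl in place of 4-chlorophenyl on an amide-type nitrogen. Among the measured compounds shown here, no measured step exchanges one aromatic ring for another: the two steps reaching compound 3 replace a saturated ring with an aromatic one and bear only loosely on this change. The expectation is therefore a step of no size beyond the scatter in this assay. The estimated step is a 1.0-fold lower number from compound 3 to compound 4 (0.01 log units; within the scatter). Compound 4 is expected near 15000 nM, in the range 6000 nM to 40000 nM.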

Compound 4, half-maximal inhibitory concentration: 64100 nM
Estimate against measurement, compound 4: 4.3-fold (0.63 log units) below, outside the stated range (above it).
By their numbers in this assay, from the lowest: compound 3; then compounds 2, 1 and 4 (each within the scatter of the next).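

In this assay, the exchange of one aromatic ring for another on the amide-type nitrogen matters: 6-chloropyridin-2-yl in place of 4-chlorophenyl gives a 4.1-fold higher number from compound 3 to compound 4 (0.62 log units; beyond the scatter), so the advantage of compound 3 over the saturated rings does not extend to compound 4. Against those rings, a 1.6-fold higher number from compound 2 to compound 4 (0.20 log units; within the scatter) and a 1.1-fold higher number from compound 1 to compound 4 (0.05 log units; within the scatter) both lie within the scatter, leaving compound 4 unseparated from the cyclohexyl and cyclopentyl amides. No available evidence accounts for the step. Going by these compounds, whether an unsubstituted pyridin-2-yl or a plain phenyl on this nitrogen would read like compound 3 or compound 4 remains open.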